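From 6-aminopyridazin-4-yl to 5-aminopyridazin-3-yl on a shared core

A few compounds are considered here, and "the series" means these few. Any claim that something is new, unique, unknown or untested is made for them only; others in the source may bear on it.

Measured in an in vitro ADME assay on microsomes from liver (Homo sapiens) for metabolic stability; a lower number here means slower removal, a higher number faster removal of the compound:
- Compound 1 `Nc1nccc(Nc2ccc(Oc3ccc(Cl)cc3)cc2)n1`: 206 mL.min-1.g-1
- Compound 2 `Nc1cccc(Nc2ccc(Oc3ccc(Cl)cc3)cc2)n1`: 100 mL.min-1.g-1
- Compound 3 `Nc1cc(Nc2ccc(Oc3ccc(Cl)cc3)cc2)cnn1`: 20 mL.min-1.g-1

Compound 3 stands lowest of the three at 20 mL.min-1.g-1 on this scale. Compound 4 `Nc1cnnc(Nc2ccc(Oc3ccc(Cl)cc3)cc2)c1` keeps the shared core and differs only in the group on a nitrogen on an aromatic ring: 5-aminopyridazin-3-yl in place of 6-aminopyridazin-4-yl on a nitrogen on an aromatic ring, with 5-aminopyridazin-3-yl in place of 6-aminopyridazin-4-yl. Three measured steps change this same group. The largest is a 10-fold lower number from compound 1 to compound 3 (1.01 log units; beyond the scatter), a large one. The others are modest: a 5.0-fold lower number from compound 2 to compound 3 (0.70 log units; beyond the scatter) and a 2.1-fold lower number from compound 1 to compound 2 (0.31 log units; beyond the scatter). Each exchange therefore moved the number beyond the scatter, but none of them tests the new group itself. Compound 3 sits at the low end, and its nearest neighbour, compound 2, has 100 mL.min-1.g-1 as its value, so a rise is expected rather than a further fall. The expected change is a 1.8-fold higher number from compound 3 to compound 4 (0.24 log units; within the scatter), with considerable uncertainty. In this assay the estimated value for compound 4 is 35 mL.min-1.g-1, with 12 mL.min-1.g-1 to 100 mL.min-1.g-1 as the expected range.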

Compound 4, intrinsic clearance in microsomes: < 14 mL.min-1.g-1
Compound 4 gave a limit, no number; the forecaster's own chance of this, stated with the estimate: 5%; middle value at least 2.5-fold (0.39 log units) from the limit.
By their numbers in this assay, from the lowest: compound 3; then compound 2; then compound 1. At a limit, below all of these: compound 4.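

In this assay compound 4 gave a limit and not a number: the limit of < 14 mL.min-1.g-1 in this assay, at which 1 of the 4 values shown sits. The new group has the same atoms and counts as 6-aminopyridazin-4-yl, joined differently, and the exchange reads as an at least 1.4-fold lower number from compound 3 to compound 4 (0.15 log units; that floor lies within the scatter), so this step alone does not separate the two compounds. The other two steps are clearer, an at least 7.1-fold lower number from compound 2 to compound 4 (0.85 log units; beyond the scatter) and an at least 14-fold lower number from compound 1 to compound 4 (1.16 log units; beyond the scatter), which shows that a second aminopyridazinyl arrangement on this nitrogen also stays well clear of the 6-aminopyridin-2-yl and 2-aminopyrimidin-4-yl compounds.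

Going by these compounds, how far the true value of compound 4 lies past its limit stays open, and with it the real size of all three steps. Also open, on these data alone, is whether a methylamino group or a hydroxyl group in place of the amine on 5-aminopyridazin-3-yl would hold the number this low.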